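Swapping Trifluoromethyl for Fluoro in Compound 2

The compounds below may be only part of what the source reports. "The series", "measured", "known", "first", "only" and "open" are said of these compounds alone.

Compound 2 `Cc1ccc(N2CC(c3nc(-c4cccc(C(F)(F)F)c4)no3)CC2=O)cc1` gives 3400 nM in an in vitro functional assay on HEK293-A cells for positive allosteric modulation of metabotropic glutamate receptor 5 (Homo sapiens), read by FLIPR and calcium flux; a lower number here means that less compound is needed, a higher number that more compound is needed for the effect. Among the numbers shown it stands highest of two; its nearest neighbour is compound 1 `O=C1CC(c2nc(-c3cccc(F)c3)no2)CN1c1ccc(Cl)cc1`, which gives 630 nM. Compound 3 `O=C1CC(c2nc(-c3cccc(C(F)(F)F)c3)no2)CN1c1ccc(F)cc1` returns only a limit, > 10000 nM. Among the measured compounds shown here, the one step measured in a single place runs an at least 2.9-fold higher number from compound 2 to compound 3 (0.46 log units; beyond the scatter), but that change is a different one, fluoro in place of methyl rather than in place of trifluoromethyl, and it ends at the limit of > 10000 nM in this assay, at which 1 of the 3 values shown sits, so its full size is unknown. Compound 4 `Cc1ccc(N2CC(c3nc(-c4cccc(F)c4)no3)CC2=O)cc1` is compound 2 with fluoro in place of trifluoromethyl on an aromatic carbon. For the measured compounds named here, no measured pair isolates this change. Compound 1 carries fluoro rather than trifluoromethyl and gives the lower number, yet it differs from compound 2 elsewhere as well, so its value is only a pointer. Compound 4 is therefore expected to give 1300 nM, between 450 nM and 4000 nM. For compound 4 this estimate means a 2.6-fold lower number from compound 2 to compound 4 (0.42 log units; beyond the scatter), expected to be modest and toward a lower number.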

Compound 4, half-maximal effective concentration: 1200 nM
The estimate for compound 4 lay 1.1-fold (0.03 log units) above the measured number, and the stated range covers the measured number.
By their numbers in this assay, from the lowest: compounds 1 and 4 (each within the scatter of the next); then compound 2. At a limit, above all of these: compound 3.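

In this assay, the change from trifluoromethyl to fluoro on an aromatic carbon, meta to a large group, can now be read on its own: a 2.8-fold lower number from compound 2 to compound 4 (0.45 log units; beyond the scatter). So at this position the smaller fluoro is tolerated, and with the rest of the molecule held constant it gives the lower number. Compounds 1 and 4 both carry fluoro at this position, and the change at the other aromatic carbon does not separate them: a 1.9-fold higher number from compound 1 to compound 4 (0.28 log units; within the scatter). No measurement shown gives a reason for the step from trifluoromethyl to fluoro.

The compounds shown leave open how an amine, a carboxylic acid or a methoxy group would behave at this position, and whether a hydrogen there would match fluoro. Compound 3 remains a limit and not a number: the limit of > 10000 nM in this assay, at which 1 of the 4 values shown sits.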